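From trifluoromethyl to carbamoyl: compound 3 and compound 4

A few compounds are considered here, and "the series" means these few. Any claim that something is new, unique, unknown or untested is made for them only; others in the source may bear on it.

In a physicochemical assay for solubility, at pH 7.4 (on this read-out lower numbers stand for lower solubility and higher numbers for higher solubility), compound 1 `CCc1ccc(NC(=O)Nc2cc(C)nc3ccccc23)cc1` gives 3300 nM, compound 2 `Cc1ccc(NC(=O)Nc2cc(C)nc3ccccc23)cc1` gives 1300 nM and compound 3 `Cc1cc(NC(=O)Nc2ccc(C(F)(F)F)cc2)c2ccccc2n1` gives 100 nM, the lowest of the three numbers. Compound 4 `Cc1cc(NC(=O)Nc2ccc(C(N)=O)cc2)c2ccccc2n1` carries carbamoyl in place of trifluoromethyl on an aromatic carbon, para to a large group (carbamoyl in place of trifluoromethyl on an aromatic carbon). Among the measured compounds shown here, no measured compound carries carbamoyl, so the closest guides are the two large steps that bring in trifluoromethyl, a 33-fold lower number from compound 1 to compound 3 (1.52 log units; beyond the scatter) and a 13-fold lower number from compound 2 to compound 3 (1.11 log units; beyond the scatter). The modest 2.5-fold lower number from compound 1 to compound 2 (0.40 log units; beyond the scatter) bears on it less. A large step to a higher number is therefore expected in this assay, estimated as a 15-fold higher number from compound 3 to compound 4 (1.18 log units; beyond the scatter). Compound 4 is expected at 1500 nM, with an estimated range of 300 nM to 7000 nM.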

Compound 4, solubility: 900 nM
Compound 4: middle estimate off by 1.7-fold (0.22 log units), on the high side, and the stated range covers the measured number.
By their numbers in this assay, from the lowest: compound 3; then compounds 4 and 2 (each within the scatter of the next); then compound 1.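

Carbamoyl is the first group at this position, on an aromatic carbon para to a large group, to bring a hydrogen-bond donor and acceptor, and in this assay it sits well above trifluoromethyl (a 9.0-fold higher number from compound 3 to compound 4 (0.95 log units; beyond the scatter)). Against methyl it cannot be told apart (a 1.4-fold lower number from compound 2 to compound 4 (0.16 log units; within the scatter)), while ethyl still keeps compound 1 the highest of the four (a 3.7-fold lower number from compound 1 to compound 4 (0.56 log units; beyond the scatter)). No measurement on hand explains these steps.

From the compounds shown here alone, how a carboxylic acid, an amine or a longer chain would read at this position remains open.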